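The source may report more compounds than this note shows. Statements on the series, on what has been measured and on what is new or still open speak of the compounds shown alone.

Measured so far in a functional assay on RPMI-8226 cells (Homo sapiens) for antiproliferative activity, with a stated time of 48 h; on this read-out lower numbers stand for stronger inhibition of growth and higher numbers for weaker inhibition of growth:
compound 1 `Cc1cc(O)c(C2=NN(c3ccc(S(N)(=O)=O)cc3)C(c3ccccc3Cl)C2)cc1Cl` — 2970 nM
compound 2 `Cc1cc(O)c(C2=NN(c3ccc(S(N)(=O)=O)cc3)C(/C=C/c3ccccc3)C2)cc1Cl` — 4950 nM

Among the measured compounds shown here, compound 2 holds the higher of these two numbers; compound 1 is its only neighbour, and the step of a 1.7-fold higher number from compound 1 to compound 2 (0.22 log units; within the scatter) lies within the scatter. Compound 3 `COc1ccc(C2CC(c3cc(Cl)c(C)cc3O)=NN2c2ccc(S(N)(=O)=O)cc2)cc1OC` differs from compound 2 by 3,4-dimethoxyphenyl in place of 2-phenylethenyl on a saturated ring carbon. The one measured exchange at this saturated ring carbon, from compound 1 to compound 2, stayed within the scatter; no measured step touches a methoxy-bearing aryl group, so nothing shown points to a shift in either direction. For compound 3 the expected step is therefore a 1.3-fold lower number from compound 2 to compound 3 (0.11 log units; within the scatter), none beyond the scatter. Compound 3 is estimated at 3800 nM (range 1300 nM to 11000 nM).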

Compound 3, concentration for 50% growth inhibition: 4100 nM
For compound 3 the middle estimate is 1.1-fold (0.03 log units) below the measured one; the range from low to high includes it.
By their numbers in this assay, from the lowest: compounds 1, 3 and 2 (each within the scatter of the next).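

this assay gives a 1.2-fold lower number from compound 2 to compound 3 (0.08 log units; within the scatter) and a 1.4-fold higher number from compound 1 to compound 3 (0.14 log units; within the scatter) on the entry of 3,4-dimethoxyphenyl at the saturated ring carbon. Both steps lie within the scatter, so a larger aryl group carrying two hydrogen-bond acceptors leaves the number level with those of 2-chlorophenyl and 2-phenylethenyl, and the three groups stay unseparated at this position. No evidence bearing on this result is available. Still open, on these data alone, is whether an amine, a carboxylic acid or a longer alkyl chain at this carbon would move the number beyond the scatter.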